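Adding a thiocarbamoyl arm to a pyridone nitrogen

The source may report more compounds than this note shows. Statements on the series, on what has been measured and on what is new or still open speak of the compounds shown alone.

Measured compounds:
Compound 1 `Cn1cccc1-c1cc(-c2ccc(Br)cc2)[nH]c(=O)c1C#N`: > 100000 nM
Compound 2 `COc1ccc(-c2cc(-c3cccn3C)c(C#N)c(=O)[nH]2)cc1OC`: 480 nM
Compound 3 `COc1ccc(-c2cc(-c3cccs3)[nH]c(=O)c2C#N)cc1`: 60200 nM

In a functional assay on SR cells (Homo sapiens) for cytotoxicity, read by sulforhodamine B assay, with a stated time of 48 h (on this read-out lower numbers stand for stronger inhibition of growth and higher numbers for weaker inhibition of growth), compound 1 gives only a limit, > 100000 nM, and no number; it sits at the limit of > 100000 nM in this assay, at which 1 of the 3 values shown sits. Compound 2 gives 480 nM in this assay. Compound 3 gives 60200 nM in this assay.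

Compound 4 `Cn1cccc1-c1cc(-c2ccc(Br)cc2)n(C(=S)Nc2ccc(F)cc2)c(=O)c1C#N` differs from compound 1 by a group of 10 heavy atoms (7 carbon, 1 nitrogen, 1 fluorine, 1 sulfur; one six-membered aromatic ring of carbon only) in place of a hydrogen atom, on an aromatic nitrogen. Among the measured compounds shown here, no step between two measured compounds is given for this change, so the size of the step in this assay is unknown; since compound 1 sits at a limit, the expectation is that compound 4 gives a number, a step towards stronger inhibition, though it may not reach beyond the usual scatter. Compound 4 is estimated at 30000 nM, between 5000 nM and 100000 nM, which would mean an expected step of an at least 3.3-fold lower number from compound 1 to compound 4 (0.52 log units; beyond the scatter).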

Compound 4, concentration for 50% growth inhibition: > 100000 nM
Compound 4: no number, only a limit; the forecaster's own chance of this, stated with the estimate: 35%; middle value at least 3.3-fold (0.52 log units) from the limit.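

Compound 1 and compound 4 both give only a limit in this assay, not a number, so no step can be read between them: the limit of > 100000 nM in this assay, at which 2 of the 4 values shown sit.

The compounds shown leave open what the thiocarbamoyl arm does to growth inhibition on a core that gives a measurable number.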